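The compounds below may be only part of what the source reports. "The series", "measured", "known", "first", "only" and "open" are said of these compounds alone.

Measured compounds in an ADME assay on MRC5 cells (Homo sapiens), read by MTT assay, with a stated time of 72 h; a higher number here means a weaker inhibitor, a lower number a stronger inhibitor:
Compound 1 `C#Cc1cn([C@@H]2O[C@H](CO)[C@@H](O)[C@H]2O)c2ncnc(NC)c12` gives > 100000 nM, a limit of the assay rather than a number.
Compound 2 `CNc1ncnc2c1c(-c1ccsc1)cn2[C@@H]1O[C@H](CO)[C@@H](O)[C@H]1O` gives > 100000 nM, likewise a limit.
Compound 3 `C#Cc1cn([C@@H]2O[C@H](CO)[C@@H](O)[C@H]2O)c2ncnc(SC)c12` gives > 100000 nM, likewise a limit.

Compound 4 `CSc1ncnc2c1c(-c1ccsc1)cn2[C@@H]1O[C@H](CO)[C@@H](O)[C@H]1O` is not yet measured in this assay. Compound 4 differs from compound 3 by thiophen-3-yl in place of ethynyl on an aromatic carbon. The same change is made from compound 1 to compound 2, namely (thiophen-3-yl in place of ethynyl on an aromatic carbon); the surroundings of the place read the same word for word, so the two are the same change, and among the compounds shown it occurs twice. The step it made, a step that the two limits leave unreadable from compound 1 to compound 2, cannot be read, since both ends sit at the limit of > 100000 nM in this assay, at which 3 of the 3 values shown sit. The cores of compound 1 and compound 3 differ by methylsulfanyl in place of methylamino on an aromatic carbon, and that step, a step that the two limits leave unreadable from compound 1 to compound 3, is equally unreadable. With every value shown sitting at the limit of > 100000 nM in this assay, at which 3 of the 3 values shown sit, nothing indicates a move off the limit, and for compound 3 to compound 4 a step that the limit leaves unreadable from compound 3 to compound 4 is expected, resting on the fact that compound 1 to compound 2 left the reading at the limit of > 100000 nM in this assay, at which 3 of the 3 values shown sit. Compound 4 is therefore expected to give 150000 nM in this assay, most likely between 50000 nM and 500000 nM.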

Compound 4, half-maximal inhibitory concentration: > 100000 nM
Compound 4 was reported as a limit (the forecaster's own chance of this, stated with the estimate: 85%); the middle value lies beyond the limit too.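

Compound 4 gives > 100000 nM in this assay, a limit of the assay and not a number. No new step can be read, neither from compound 3 to compound 4 nor from compound 2 to compound 4: the limit of > 100000 nM in this assay, at which 4 of the 4 values shown sit.

The compounds shown leave open how far each lies beyond the limit, and whether either change alters the reading in this assay.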